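A few compounds are considered here, and "the series" means these few. Any claim that something is new, unique, unknown or untested is made for them only; others in the source may bear on it.

Measured compounds:
compound 1 `CCOC(=O)c1ccc(NC(=O)NCc2cocn2)cc1`: 27600 nM
compound 2 `O=C(NCc1ccncc1)Nc1ccc(S(=O)(=O)NCc2ccccc2)cc1`: 102 nM

The series is read in an assay on isolated protein for activation of Nicotinamide phosphoribosyltransferase (Homo sapiens); a lower number here means that less compound is needed, a higher number that more compound is needed for the effect. Compound 1 gives 27600 nM in this assay, and compound 2 gives 102 nM there. Within the data shown here, compound 2 therefore stands lowest of the two numbers known so far; its nearest neighbour, compound 1, sits far higher, well beyond the scatter, and the two share no single-point change, so the gap between them is noted only as the two values show it.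

The next compound, compound 3 `O=C(NCc1ccncc1)Nc1ccc(S(=O)(=O)c2ccccc2)cc1`, is compound 2 with one change: phenyl in place of benzylamino on a sulfonyl sulfur. Among the measured compounds shown here, since no single-point step between measured compounds exists in the set, the size of this step has no direct precedent in this assay. Judged only from the change itself, a moderate move toward a higher number, somewhat beyond the scatter, is expected for compound 3, so the step of a 2.9-fold higher number from compound 2 to compound 3 (0.47 log units; beyond the scatter) is the estimated outcome. Compound 3 is accordingly expected to give about 300 nM in this assay, with a likely range of 80 nM to 1500 nM.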

Compound 3, half-maximal effective concentration: 85 nM
Compound 3: middle estimate off by 3.5-fold (0.55 log units), on the high side, and the stated range covers the measured number.
By their numbers in this assay, from the lowest: compounds 3 and 2 (each within the scatter of the next); then compound 1.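

In this assay, the step of a 1.2-fold lower number from compound 2 to compound 3 (0.08 log units; within the scatter) for phenyl in place of benzylamino on a sulfonyl sulfur lies within the scatter, so the two compounds cannot be told apart at this position. Among these compounds, this is the first single-point comparison, and it shows that the sulfonyl sulfur can carry either an aromatic ring attached directly or benzylamino with no readable change in the number, even though the hydrogen-bond donor of benzylamino does not enter with phenyl. No measurement available here bears on why the swap leaves the number within the scatter.

On these data alone, only these two groups have been compared on the sulfonyl sulfur, so it remains open whether the same tolerance extends to a small alkyl group such as methyl, a cyclic amine such as piperidine, a carboxylic acid-bearing chain or a longer chain such as phenethylamino. As far as these compounds go, it is also open whether a substituent such as fluorine or methoxy on the phenyl ring of compound 3 would move the number beyond the scatter.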